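From methoxy to dimethylamino on a shared core

The source may hold more compounds than are shown below. What is called first, only, known or untested is meant among the compounds shown, and "the series" means these compounds.

- Compound 1 `CCCCCCCCCC(CCO)n1cnc2c(N(C)C)ncnc21` gives 9810 nM
- Compound 2 `CCCCCCCCCCC(CCO)n1cnc2c(Cl)ncnc21` gives 4930 nM
- Compound 3 `CCCCCCCCCCC(CCO)n1cnc2c(OC)ncnc21` gives 7530 nM

All three values come from a functional assay on HCT-116 cells (Homo sapiens) for antiproliferative activity, read by MTT assay, with a stated time of 48 h (on this read-out lower numbers stand for stronger inhibition and higher numbers for weaker inhibition), and compound 3 stands second highest of them, within the scatter of both compound 1 and compound 2. Compound 4 `CCCCCCCCCCC(CCO)n1cnc2c(N(C)C)ncnc21` has not yet been measured. Its change from compound 3 is dimethylamino in place of methoxy on an aromatic carbon and the rest of the molecule stays the same.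

Two measurements bear on this change. For the measured compounds named here, the one measured swap at this place is a 1.5-fold higher number from compound 2 to compound 3 (0.18 log units; within the scatter) and it put methoxy in place of chloro. Compound 1 already carries dimethylamino, on a shorter chain, and gives 9810 nM in the same test. Neither points to a large shift, so no step beyond the scatter is expected in this assay for this change. The expected step is a 1.1-fold higher number from compound 3 to compound 4 (0.03 log units; within the scatter) and it remains an estimate. Estimated for compound 4 is 8000 nM with 4500 nM to 14000 nM as the expected range.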

Compound 4, half-maximal inhibitory concentration: 5490 nM
Compound 4: the middle estimate sits 1.5-fold (0.16 log units) above what was measured; the range from low to high includes it.
By their numbers in this assay, from the lowest: compounds 2, 4, 3 and 1 (each within the scatter of the next).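

Dimethylamino in place of methoxy on an aromatic carbon gives a 1.4-fold lower number from compound 3 to compound 4 (0.14 log units; within the scatter) in this assay and so adds a second measured swap at this place. Dimethylamino in place of chloro gives a 1.1-fold higher number from compound 2 to compound 4 (0.05 log units; within the scatter) as well, so chloro, methoxy and dimethylamino cannot be told apart at this place in this test. With dimethylamino held fixed, methyl in place of hydrogen on a saturated chain carbon gives a 1.8-fold lower number from compound 1 to compound 4 (0.25 log units; within the scatter) and so this small change at the chain end stays inside the scatter too.

As far as these compounds go, whether a primary amine or a carboxylic acid at this place, or a much shorter chain, would give a step beyond the scatter stays open. Nothing available here speaks to why these steps are so small.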